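From compound 1 to compound 4: an expected half-life

The source may report more compounds than this note shows. Statements on the series, on what has been measured and on what is new or still open speak of the compounds shown alone.

Compound 1 `NS(=O)(=O)c1cc(-c2nnc(CN3CCN(c4ccccc4)CC3)o2)c(Cl)cc1SCc1ccccc1` gives 0.33 h in an ADME assay on microsomes from liver (Homo sapiens) for metabolic stability, read by LC-MS, using NADPH, tested at 5 uM; a higher number here means that the compound lasts longer, a lower number that the compound disappears faster.
Compound 2 `NS(=O)(=O)c1cc(-c2nnc(CN3CCN(c4ccc(Cl)cc4)CC3)o2)c(Cl)cc1SCc1ccccc1` gives 0.455 h.
Compound 3 `NS(=O)(=O)c1cc(-c2nnc(CN3CCN(c4ccc(F)cc4)CC3)o2)c(Cl)cc1SCc1ccccc1` gives 0.527 h.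

Compound 1 has the lowest of the three numbers, though its neighbours sit close: compound 2 is nearest, with a 1.4-fold higher number from compound 1 to compound 2 (0.14 log units; within the scatter), and compound 3 furthest, with a 1.6-fold higher number from compound 1 to compound 3 (0.20 log units; within the scatter); between the two there is a 1.2-fold higher number from compound 2 to compound 3 (0.06 log units; within the scatter). Compound 4 `NS(=O)(=O)c1cc(-c2nnc(CNS(=O)(=O)c3ccc(Cl)cc3)o2)c(Cl)cc1SCc1ccccc1` differs from compound 1 by ((4-chlorophenyl)sulfonyl)amino in place of 4-phenylpiperazin-1-yl on a saturated chain carbon bound to an aromatic carbon. Going by the values given here, none of the measured steps touches this part of the molecule; each swaps a hydrogen or halogen on an aromatic carbon of the group that leaves, and all stayed within the scatter. Among the compounds with values here, no measured step therefore bears directly on the change, and the expectation rests only on the narrow spread of the three values. The expected step is a 1.4-fold higher number from compound 1 to compound 4 (0.13 log units; within the scatter), with no confident direction beyond the scatter. Compound 4 is therefore estimated at 0.45 h, with a range from 0.18 h to 1.1 h.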

Compound 4, half-life: 0.197 h
Compound 4: the middle estimate sits 2.3-fold (0.36 log units) above what was measured; the range from low to high includes it.
By their numbers in this assay, from the lowest: compounds 4, 1, 2 and 3 (each within the scatter of the next, the first and the last beyond it).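

In this assay, exchanging the whole 4-phenylpiperazin-1-yl group for ((4-chlorophenyl)sulfonyl)amino on the saturated chain carbon gives a 1.7-fold lower number from compound 1 to compound 4 (0.22 log units; within the scatter). The earlier steps shown here only swapped a hydrogen or halogen on an aromatic carbon, whereas this one removes the six-membered non-aromatic ring and adds a sulfonyl-bearing linker, and the half-life still stays within the scatter. Nothing available explains this result. As far as these compounds go, what a morpholine or a carboxylic acid would do on this chain carbon remains open. So does the effect of removing the chloro from the entering group.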